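The source may hold more compounds than are shown below. What is called first, only, known or untested is meant among the compounds shown, and "the series" means these compounds.

Measured compounds:
compound 1, `CCN(CC)CCNC(=O)c1ccc(C(CC)(CC)c2ccc(OCC(=O)C(C)(C)C)c(C)c2)n1CC`, 91 nM in an assay on HL-60 cells for agonist activity at vitamin D3 receptor (Homo sapiens), read by microscopy, with a stated time of 96 h; on this read-out lower numbers stand for an effect already at smaller amounts and higher numbers for an effect only at larger amounts of compound
compound 2, `CCN(CC)CCNC(=O)c1ccc(C(CC)(CC)c2ccc(OCC(O)C(C)(C)C)c(C)c2)n1CC`, 110 nM in this assay
compound 3, `CCn1c(C(=O)N(C)CC(=O)O)ccc1C(CC)(CC)c1ccc(OCC(O)C(C)(C)C)c(C)c1`, 740 nM in this assay

Among these three values compound 1 gives the lowest number, with compound 2 nearest (a 1.2-fold higher number from compound 1 to compound 2 (0.08 log units; within the scatter)) and compound 3 furthest away. The two steps measured so far sit at different places on the shared core: the step from compound 1 to compound 2 changes the chain on the aromatic oxygen and stays within the scatter, whereas the step from compound 2 to compound 3, a change on the carbonyl carbon, gives a modest rise (a 6.7-fold higher number from compound 2 to compound 3 (0.83 log units; beyond the scatter)).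

Compound 4, `CCn1c(C(=O)OCc2ccc(F)cc2)ccc1C(CC)(CC)c1ccc(OCC(=O)C(C)(C)C)c(C)c1`, has not yet been measured. It differs from compound 1 at that same carbonyl carbon: (4-fluorobenzyl)oxy in place of (2-(diethylamino)ethyl)amino on a carbonyl carbon. Going by the values given here, only the step from compound 2 to compound 3 bears on a change at this site, and it moved the number upward beyond the scatter. The change in compound 4 is of a different kind, an ester in place of an amide, so the size is uncertain, but a rise of similar order is the most reasonable expectation; an outcome within the scatter cannot be excluded. Compound 4 is therefore expected to show a higher number than compound 1 in this assay, with a step of roughly a 4.4-fold higher number from compound 1 to compound 4 (0.64 log units; beyond the scatter), giving an estimate of 400 nM, between 120 nM and 1500 nM.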

Compound 4, half-maximal effective concentration: 9500 nM
The estimate for compound 4 lay 24-fold (1.38 log units) below the measured number, and the stated range ends below it.
By their numbers in this assay, from the lowest: compounds 1 and 2 (each within the scatter of the next); then compound 3; then compound 4.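

In this assay the replacement of (2-(diethylamino)ethyl)amino by (4-fluorobenzyl)oxy on the carbonyl carbon gives a 100-fold higher number from compound 1 to compound 4 (2.02 log units; beyond the scatter) and so shows that this position can move the number far more than the earlier change there suggested (a 6.7-fold higher number from compound 2 to compound 3 (0.83 log units; beyond the scatter)). Both changes at this carbonyl carbon now raise the number beyond the scatter, and neither of the two replacing groups keeps it near the value of compound 1. The new step exchanges the amide hydrogen, both nitrogens and the open chain for an ester oxygen, a fluorine and a six-membered aromatic ring all at once, and no measurement offered here accounts for the size of the rise.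

The compounds shown leave open which of these differences carries the step, a question that a 4-fluorobenzyl amide or a methyl ester on the same carbonyl carbon would help to separate. Going by these compounds, it also remains open whether the step would be of similar size with 1-hydroxy-2,2-dimethylpropyl in place of (tert-butyl)carbonyl on the chain at the aromatic oxygen.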